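Ring size on the sulfonyl nitrogen of a carbamate series

A few compounds are considered here, and "the series" means these few. Any claim that something is new, unique, unknown or untested is made for them only; others in the source may bear on it.

Measured compounds in an assay on liver for inhibition of sterol O-acyltransferase 1 (Rattus norvegicus), using microsomes; on this read-out higher numbers stand for weaker inhibition and lower numbers for stronger inhibition:
- compound 1 `CC(C)c1cccc(C(C)C)c1NC(=O)NS(=O)(=O)N1CCCCC1` gives 17000 nM
- compound 2 `CC(C)c1cccc(C(C)C)c1NC(=O)NS(=O)(=O)Nc1c(C(C)C)cccc1C(C)C` gives 11000 nM
- compound 3 `CC(C)c1cccc(C(C)C)c1OC(=O)NS(=O)(=O)N1CCCC1` gives 53000 nM

Compound 3 stands at the highest number of the three, beyond the scatter from both compound 1 and compound 2, so it is the weakest inhibitor among them in this assay. Compound 4 `CC(C)c1cccc(C(C)C)c1OC(=O)NS(=O)(=O)N1CCCCC1` differs from compound 3 in one place: piperidin-1-yl in place of pyrrolidin-1-yl on a sulfonyl sulfur. Within the data shown here, no measured pair shows this change on its own, and compound 1 carries the larger ring on a different linker, so no direct comparison exists. For compound 4 a modest move toward stronger inhibition is expected, with the step of a 1.5-fold lower number from compound 3 to compound 4 (0.18 log units; within the scatter) possibly staying within the scatter. Compound 4 is estimated at 35000 nM, between 12000 nM and 100000 nM.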

Compound 4, half-maximal inhibitory concentration: > 100000 nM
Compound 4 was reported as a limit; the forecaster's own chance of this, stated with the estimate: 10%; middle value at least 2.8-fold (0.45 log units) from the limit.
By their numbers in this assay, from the lowest: compounds 2 and 1 (each within the scatter of the next); then compound 3. At a limit, above all of these: compound 4.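

The value of compound 4 in this assay is a limit, not a number: the limit of > 100000 nM in this assay, at which 1 of the 4 values shown sits. On a sulfonyl sulfur, piperidin-1-yl in place of pyrrolidin-1-yl gives an at least 1.8-fold higher number from compound 3 to compound 4 (0.27 log units; that floor lies within the scatter), so in this carbamate series the six-membered ring brings no gain in inhibition over the five-membered one. Among these compounds, none of the earlier compounds isolated this change.

On these data alone, how far the true number of compound 4 lies past its limit remains open. So does whether a morpholin-4-yl or dimethylamino group at this place would give a lower number than pyrrolidin-1-yl.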